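The source may hold more compounds than are shown below. What is called first, only, known or untested is meant among the compounds shown, and "the series" means these compounds.

Compound 1 `Cc1ncnc2c1c(I)cn2[C@@H]1O[C@H](CO)[C@@H](O)[C@H]1O` in an ADME assay on BJ cells (Homo sapiens), read by MTT assay, with a stated time of 72 h (a higher number here means a weaker inhibitor, a lower number a stronger inhibitor), gives > 100000 nM, which is a limit of the assay rather than a number. Compound 2 `C#Cc1cn([C@@H]2O[C@H](CO)[C@@H](O)[C@H]2O)c2ncnc(C)c12` in this assay gives 50 nM. Compound 3 `C#Cc1cn([C@@H]2O[C@H](CO)[C@@H](O)[C@H]2O)c2nc(C)nc(N)c12` in this assay gives > 100000 nM, again a limit and not a number.

Compounds 1 and 2 share a core. The change from compound 2 to compound 1 is iodo in place of ethynyl on an aromatic carbon and it brought an at least 2000-fold higher number from compound 2 to compound 1 (3.30 log units; beyond the scatter). Compound 3 has a different core from compound 2; that difference is not broken down here. Compound 4 `Cc1nc(N)c2c(I)cn([C@@H]3O[C@H](CO)[C@@H](O)[C@H]3O)c2n1` arises from compound 3 by the same change, (iodo in place of ethynyl on an aromatic carbon), at a place described in the same words.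

Compound 3 already sits at the limit of > 100000 nM in this assay, at which 2 of the 3 values shown sit, and the earlier change only weakened inhibition. The expected step is therefore a step that the limit leaves unreadable from compound 3 to compound 4, resting on the earlier step of an at least 2000-fold higher number from compound 2 to compound 1 (3.30 log units; beyond the scatter). Compound 4 is estimated at 200000 nM, most likely reported as a limit, between 50000 nM and 1000000 nM.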

Compound 4, half-maximal inhibitory concentration: 24600 nM
The estimate for compound 4 lay 8.1-fold (0.91 log units) above the measured number, and the stated range ends above it.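

Iodo in place of ethynyl gave an at least 4.0-fold lower number from compound 3 to compound 4 (0.60 log units; beyond the scatter) in this assay, so the number moved in the opposite direction to the earlier pair. This change therefore did not carry over from one core to the other, either in size or in direction: the same change on two cores in this assay, an at least 2000-fold higher number (3.30 log units; beyond the scatter) from compound 2 to compound 1 and an at least 4.0-fold lower number (0.60 log units; beyond the scatter) from compound 3 to compound 4, at least 8100-fold (3.91 log units) apart, beyond the scatter of two such steps This does not give the true size of the step, and compound 3 is recorded only as a limit of the assay: the limit of > 100000 nM in this assay, at which 2 of the 4 values shown sit.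

Which part of the difference between the two cores goes with this reversal remains open. Also open, on these data alone, is how a nitrile or a longer chain at the same place would behave on each core.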